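The source may report more compounds than this note shows. Statements on the series, on what has been measured and on what is new or still open speak of the compounds shown alone.

In a functional assay on SK-BR-3 cells (Homo sapiens) for cytotoxicity, read by MTT assay, with a stated time of 72 h (a higher number here means a weaker inhibitor, a lower number a stronger inhibitor), compound 1 `Nc1ccc(Nc2c(C(=O)NCc3ccc(F)cc3)nc(Br)c3cccnc23)cc1` gives 4000 nM. Going by the values given here, this is the only number available, so it cannot yet be ranked against anything else. Compound 2 `N[C@H]1CC[C@H](Nc2c(C(=O)NCc3cccs3)nc(Br)c3cccnc23)CC1` offers no comparison, since its entry reads "not determined" (no result reported).

Compound 3 `NCCCCCCNc1c(C(=O)NCc2ccc(F)cc2)nc(Br)c2cccnc12` keeps the rest of compound 1 and alters a single group, with 6-aminohexyl in place of 4-aminophenyl on a nitrogen on an aromatic ring. A ring leaves and an open chain enters, while the amino group stays at the end of the new substituent.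

Among the compounds with values here, no measured pair shows what such a swap does in this assay, so the data point in no particular direction. The working expectation is therefore no change beyond the usual scatter, with a wide margin for the unknown. The estimate starts from the one measured anchor, compound 1 at 4000 nM. In numbers, the estimated change is a 1.3-fold lower number from compound 1 to compound 3 (0.12 log units; within the scatter). Compound 3 is expected to come in at about 3000 nM, with an estimated range from 800 nM to 12000 nM.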

Compound 3, half-maximal inhibitory concentration: 3000 nM
Estimate against measurement, compound 3: no gap at the digits printed, within the range that was stated.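

In this assay, going by these compounds alone, the step from 4-aminophenyl to 6-aminohexyl on a nitrogen on an aromatic ring is a 1.3-fold lower number from compound 1 to compound 3 (0.12 log units; within the scatter), which gives the first measured comparison at this position and leaves the two compounds indistinguishable. The two groups match in their counts of heavy atoms, hydrogen-bond donors and acceptors, and the clearest difference between them is that one has a six-membered aromatic ring and the other has no ring, so in this one pair, an open chain can stand in for the ring with no change that this read-out can separate from the scatter. No supporting measurement is available to explain this result.

On these data alone, both groups end in an amino group, so the role of that amine remains open, and a plain hexyl chain or a chain ending in a carboxylic acid would address it. As far as these compounds go, it also remains open whether chain length matters at this position, which a shorter or longer chain ending in an amine could test, and whether this single pair holds for other groups on the shared core.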